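From 3,4-dihydroxyphenyl to 4-methylphenyl in the series

The source may report more compounds than this note shows. Statements on the series, on what has been measured and on what is new or still open speak of the compounds shown alone.

In a functional assay on COLO 205 cells (Homo sapiens) for inhibition, read by MTT assay, with a stated time of 48 h (on this read-out lower numbers stand for stronger inhibition and higher numbers for weaker inhibition), compound 3 (`COc1cc(C(=O)/C=C/c2ccc(O)c(O)c2)cc(OC)c1OC`) gives 19800 nM as its value. Compound 1 (`COc1cccc(/C=C/C(=O)c2cc(OC)c(OC)c(OC)c2)c1OC`) gives 13200 nM in this assay and the two values lie within the scatter of each other. Compound 2 (`COc1cc(/C=C/C(=O)c2cc(OC)c(OC)c(OC)c2)ccc1O`) reads > 100000 nM in this assay and this is a limit of the assay, not a number.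

Compound 4 (`COc1cc(C(=O)/C=C/c2ccc(C)cc2)cc(OC)c1OC`) carries 4-methylphenyl in place of 3,4-dihydroxyphenyl on a double-bonded chain carbon bound to a double-bonded chain carbon. For the measured compounds named here, the one measured step on that ring is an at least 5.0-fold lower number from compound 2 to compound 3 (0.70 log units; beyond the scatter) for hydrogen in place of methyl on an oxygen on an aromatic ring, and it lies beyond the scatter. That step shows that a small change on this ring can move the result, but it is not the change made here. Compound 1 has no hydroxyl on the ring in question and still gives 13200 nM as a measured number. Compound 2 has a hydroxyl there and goes against any simple rule linking hydroxyl to the result.

The expected step is a 1.3-fold lower number from compound 3 to compound 4 (0.12 log units; within the scatter) and it is estimated to stay within the scatter. The estimated value for compound 4 is 15000 nM with an expected range of 5000 nM to 70000 nM for this series.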

Compound 4, half-maximal inhibitory concentration: 41500 nM
The estimate for compound 4 lay 2.8-fold (0.44 log units) below the measured number, and the stated range covers the measured number.
By their numbers in this assay, from the lowest: compounds 1 and 3 (each within the scatter of the next); then compound 4. At a limit, above all of these: compound 2.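

In this assay, for the compounds shown here, a 2.1-fold higher number from compound 3 to compound 4 (0.32 log units; beyond the scatter), the first step on this ring measured between two actual numbers, so 4-methylphenyl in place of 3,4-dihydroxyphenyl on a double-bonded chain carbon bound to a double-bonded chain carbon weakens inhibition modestly. The earlier step on this ring, an at least 5.0-fold lower number from compound 2 to compound 3 (0.70 log units; beyond the scatter), rests on a limit and gives only a bound, whereas the new step has a definite size. Compound 2 reads > 100000 nM, which is a limit of the assay and not a number, so its distance from the other compounds has no definite size: the limit of > 100000 nM in this assay, at which 1 of the 4 values shown sits.

This single pair changes the two hydroxyl groups and the methyl together, so the step cannot be divided between losing the hydroxyl groups and gaining the methyl. On these data alone, it remains open whether an amine or a carboxylic acid in place of 3,4-dihydroxyphenyl, or a longer chain in place of the methyl on 4-methylphenyl, would move the number further in either direction.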